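The source may hold more compounds than are shown below. What is called first, only, known or untested is meant among the compounds shown, and "the series" means these compounds.

Compound 2 `Cc1ccc(-c2cc(-c3ccc(Cl)o3)cc(-c3ccsc3)n2)o1` is the starting point for the next step. In a functional assay on HCT-15 cells (Homo sapiens) for cytotoxicity, in the presence of a further agent that is not named here (a higher number here means a weaker inhibitor, a lower number a stronger inhibitor), compound 2 reaches only the limit of the assay, > 50000 nM, so no number is known for it. Compound 1 `Clc1ccc(-c2cc(-c3ccsc3)nc(-c3ccccc3Cl)c2)o1` gives 4570 nM in this assay. Among the measured compounds shown here, the single measured step, an at least 10-fold higher number from compound 1 to compound 2 (1.03 log units; beyond the scatter), is large, and it rests on the limit (the limit of > 50000 nM in this assay, at which 1 of the 2 values shown sits), so its true size is not known. Compound 3 `Clc1ccc(-c2cc(-c3ccsc3)nc(-c3ccccn3)c2)o1` differs from compound 2 by pyridin-2-yl in place of 5-methylfuran-2-yl on an aromatic carbon. The step from compound 1 to compound 2 is the only one that bears on this change, as it exchanges the group on the same aromatic carbon, and that step reached only a limit. Compound 3 is expected to sit between compound 1 and the limit. The expected step in this assay is an at least 3.3-fold lower number from compound 2 to compound 3 (0.52 log units; beyond the scatter). The estimate for compound 3 in this assay is 15000 nM, with a range from 3000 nM to 50000 nM.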

Compound 3, half-maximal inhibitory concentration: > 50000 nM
Compound 3 gave a limit, no number; the forecaster's own chance of this, stated with the estimate: 40%; at least 3.3-fold (0.52 log units) between middle value and limit.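

In this assay compound 3 sits at a limit of the assay, > 50000 nM, and gives no number. Pyridin-2-yl in place of 2-chlorophenyl gives an at least 10-fold higher number from compound 1 to compound 3 (1.03 log units; beyond the scatter), so a six-membered aromatic ring on this carbon does not by itself retain the measured value of compound 1, and of the three compounds only the one with 2-chlorophenyl gives a number. The step between compound 2 and compound 3 cannot be read, and 5-methylfuran-2-yl and pyridin-2-yl cannot be ranked: the limit of > 50000 nM in this assay, at which 2 of the 3 values shown sit.

From the compounds shown here alone, it remains open whether the chlorine atom or the phenyl ring of 2-chlorophenyl accounts for the number seen with compound 1. Going by these compounds, how an unsubstituted phenyl, a 2-methoxyphenyl or an aminomethyl group would read at this position also remains open.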